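The source may hold more compounds than are shown below. What is called first, only, known or untested is meant among the compounds shown, and "the series" means these compounds.

Measured compounds:
- compound 1, `Cn1c(=O)c(S(=O)(=O)c2ccc(F)cc2F)cc2cnc(Nc3ccc4cc[nH]c4c3)nc21`: 5000 nM
- compound 2, `Cn1c(=O)c(S(=O)(=O)c2ccc(F)cc2)cc2cnc(Nc3cccc4[nH]ccc34)nc21`: 750 nM
- compound 3, `Cn1c(=O)c(S(=O)(=O)c2ccc(F)cc2)cc2cnc(Nc3ccc4[nH]cnc4c3)nc21`: 10000 nM

In a functional assay on DU-145 cells (Homo sapiens) for inhibition, read by trypan blue exclusion, with a stated time of 72 h (on this read-out higher numbers stand for weaker inhibition and lower numbers for stronger inhibition), compound 3 stands at the highest number of the three; compound 1 lies within the scatter of it, while compound 2 lies well below it. Among the compounds with values here, the one step in this set, a 13-fold higher number from compound 2 to compound 3 (1.12 log units; beyond the scatter), is large and runs toward weaker inhibition when the benzimidazole replaces the indole.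

Compound 4, `Cn1c(=O)c(S(=O)(=O)c2ccc(F)cc2)cc2cnc(Nc3ccc4cc[nH]c4c3)nc21`, is the unmeasured one; it differs from compound 3 by 1H-indol-6-yl in place of 1H-benzimidazol-5-yl on a nitrogen on an aromatic ring. The step from compound 2 to compound 3 is the only one that bears on this change, and it points the other way: returning to an indole-type group is expected to lower the number. The indole here is attached at a different position than in compound 2, and compound 1, which carries the same 1H-indol-6-yl group on a different sulfone, sits at a number within the scatter of compound 3, so only part of that gain is expected. For compound 4 the step is expected to be a 4.0-fold lower number from compound 3 to compound 4 (0.60 log units; beyond the scatter), giving an estimate of 2500 nM with a range from 800 nM to 8000 nM.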

Compound 4, half-maximal inhibitory concentration: 10000 nM
Compound 4: the middle estimate sits 4.0-fold (0.60 log units) below what was measured; the whole stated range lies below it.
By their numbers in this assay, from the lowest: compound 2; then compounds 1, 3 and 4 (each within the scatter of the next).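

In this assay, 1H-indol-6-yl in place of 1H-benzimidazol-5-yl gives no change at the digits printed from compound 3 to compound 4 (within the scatter) and so the ring nitrogen that leaves with the benzimidazole does not by itself separate compound 3 from compound 2. With the indole kept and only its point of attachment to the amino nitrogen changed, the series shows a 13-fold higher number from compound 2 to compound 4 (1.12 log units; beyond the scatter) and so, among these compounds, the large difference follows the 1H-indol-4-yl group. Hydrogen in place of fluoro on the aromatic carbon of the sulfone ring gives a 2.0-fold higher number from compound 1 to compound 4 (0.30 log units; within the scatter) and this fluoro therefore has no effect here beyond the scatter.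

No measurement shown here explains why the attachment point matters. Going by these compounds, whether the 1H-indol-4-yl group keeps the number of compound 2 when it carries a methyl group or an amine remains open.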